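Piperidinyl in place of hydrogen on the benzyl ring

A few compounds are considered here, and "the series" means these few. Any claim that something is new, unique, unknown or untested is made for them only; others in the source may bear on it.

Compound 3 `Nc1cc(Cc2ccn(Cc3ccccc3)n2)c2nn[nH]c2n1` carries an unsubstituted benzyl group on the shared core. In an assay on isolated protein for inhibition of Myeloperoxidase (Homo sapiens), with a stated time of 10 min (on this read-out higher numbers stand for weaker inhibition and lower numbers for stronger inhibition), compound 3 gives 120 nM, the highest number of the three measured compounds. Compound 1 `Nc1cc(Cc2ccn(Cc3cccc(-c4ccccc4)c3)n2)c2nn[nH]c2n1` bears a phenyl on that benzyl ring and gives 55 nM; compound 2 `Nc1cc(Cc2ccn(Cc3cccc(Oc4cccc5c4CNC5)c3)n2)c2nn[nH]c2n1` bears an ether-linked bicyclic group at the same carbon and gives 26 nM. Both steps toward compound 3 go the same way: a 2.2-fold higher number from compound 1 to compound 3 (0.34 log units; beyond the scatter) and a 4.6-fold higher number from compound 2 to compound 3 (0.66 log units; beyond the scatter), each beyond the scatter but modest.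

Compound 4 `Nc1cc(Cc2ccn(Cc3cccc(C4CCNCC4)c3)n2)c2nn[nH]c2n1` is not yet measured. It differs from compound 3 by piperidin-4-yl in place of hydrogen on an aromatic carbon, so a substituent again enters the carbon that is bare in compound 3 and occupied in compound 1 and compound 2. Both measured steps bear on this change and both point to a lower number when that carbon is occupied, by a modest amount in each case. A lowering of similar, modest size is therefore expected in this assay, with no basis in the measured set for anything larger.

For compound 4 the expected value in this assay is estimated at 45 nM, in a range from 20 nM to 110 nM. The expected step is a 2.7-fold lower number from compound 3 to compound 4 (0.43 log units; beyond the scatter).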

Compound 4, half-maximal inhibitory concentration: 100 nM
Compound 4: the middle estimate sits 2.2-fold (0.35 log units) below what was measured; low and high end bracket the measured number.
By their numbers in this assay, from the lowest: compound 2; then compounds 1, 4 and 3 (each within the scatter of the next, the first and the last beyond it).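

In this assay, occupying the carbon that is bare in compound 3 does not by itself move the read-out: with piperidin-4-yl on that aromatic carbon the step is within the scatter (a 1.2-fold lower number from compound 3 to compound 4 (0.08 log units; within the scatter)), so the lowering seen with phenyl and with the ether-linked bicyclic group does not extend to every group placed there. The step from the phenyl compound is also within the scatter (a 1.8-fold higher number from compound 1 to compound 4 (0.26 log units; within the scatter)), whereas the step from the ether-linked bicyclic compound lies beyond it (a 3.8-fold higher number from compound 2 to compound 4 (0.59 log units; beyond the scatter)), so the result separates piperidin-4-yl from the bicyclic group but not from phenyl or from hydrogen, even though phenyl and hydrogen are separated from each other beyond the scatter. Nothing on hand explains why these groups at the same carbon differ in this way.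

Open, on these data alone, is whether the ring nitrogen of piperidin-4-yl matters at this carbon, a question that a cyclohexyl group in its place would address. Also open, as far as these compounds go, is whether the oxygen link or the bicyclic group of compound 2 accounts for its gap to compound 4, which a phenoxy group at the same carbon would help to separate.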